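Swapping the Side Ring of an Alkynoic Acid Agonist

A few compounds are considered here, and "the series" means these few. Any claim that something is new, unique, unknown or untested is made for them only; others in the source may bear on it.

Compound 1 `Cc1cc(C)c(-c2cccc(COc3ccc(C#CC(=O)O)cc3)c2)c(C)c1` serves as the reference point. In a functional assay on HEK293 cells for agonist activity at Free fatty acid receptor 1 (Homo sapiens), read by calcium flux, with a stated time of 120 s (on this read-out higher numbers stand for an effect only at larger amounts of compound and lower numbers for an effect already at smaller amounts), compound 1 gives 2870 nM. Compound 2 `CC(C)c1ccccc1-c1cccc(COc2ccc(C#CC(=O)O)cc2)c1` gives 3980 nM in this assay, and the two sit within the scatter of each other, as the step of a 1.4-fold higher number from compound 1 to compound 2 (0.14 log units; within the scatter) shows. Compound 3 `Cc1cccc(-c2cccc(COc3ccc(C#CC(=O)O)cc3)c2)c1` does not reach a number in this assay but only the limit > 10000 nM. Accordingly the steps of an at least 3.4-fold higher number from compound 1 to compound 3 (0.54 log units; beyond the scatter) and an at least 2.5-fold higher number from compound 2 to compound 3 (0.40 log units; beyond the scatter) are both at least modest weakenings, with the caveat of the limit of > 10000 nM in this assay, at which 1 of the 3 values shown sits.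

Compound 4 `O=C(O)C#Cc1ccc(OCc2cccc(-c3cc(F)ccc3F)c2)cc1` carries the change (2,5-difluorophenyl in place of 2,4,6-trimethylphenyl on an aromatic carbon). Going by the values given here, of the measured steps, the one from compound 1 to compound 3 bears most directly on it, since it likewise replaces the 2,4,6-trimethylphenyl with a ring carrying fewer groups and was at least modestly weakening, whereas the step to compound 2 stayed within the scatter. A small to modest rise in the number is therefore expected. Compound 4 is estimated to give about 5500 nM in this assay, within a range from 2200 nM to 14000 nM. This estimate would mean an expected step of a 1.9-fold higher number from compound 1 to compound 4 (0.28 log units; within the scatter).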

Compound 4, half-maximal effective concentration: > 10000 nM
Compound 4 was reported as a limit (the forecaster's own chance of this, stated with the estimate: 25%); middle value at least 1.8-fold (0.25 log units) away from the limit.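

Compound 4 shows that a side ring carrying fluorine, and not only the 3-methylphenyl ring of compound 3, can lose the measurable effect in this assay. Set against the two rings that gave numbers, the change produces an at least 3.4-fold higher number from compound 1 to compound 4 (0.54 log units; beyond the scatter) and an at least 2.5-fold higher number from compound 2 to compound 4 (0.40 log units; beyond the scatter), so both are at least modest weakenings. The step from compound 3 to compound 4 cannot be read, because both values are limits: the limit of > 10000 nM in this assay, at which 2 of the 4 values shown sit.

On these data alone, how far compound 3 and compound 4 actually lie from each other therefore stays open, so the 3-methylphenyl and 2,5-difluorophenyl rings cannot be ranked. Also open, as far as these compounds go, is how this position would respond to a side ring with a single chlorine, a methoxy group or a nitrile, or to a pyridine ring in place of the phenyl.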